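This account rests on a few compounds, and the source may have more. Where it says the series, first, only, none or still open, it means among the compounds named here.

Going by the values given here, compound 1 `C[Se]/C(=N\C(=O)c1cc2ccccc2s1)NC(=O)c1cc2ccccc2s1` is one of three compounds measured so far in a functional assay on HT-29 cells (Homo sapiens) for cytotoxicity, read by MTT assay, with a stated time of 72 h (a higher number here means a weaker inhibitor of growth, a lower number a stronger inhibitor of growth), where it gives 5620 nM. Two related compounds share its overall shape but carry a different core on the two amide arms. Compound 2 `C[Se]/C(=N\C(=O)c1cnc2ccccc2c1)NC(=O)c1cnc2ccccc2c1` gives 200 nM. Compound 3 `O=C(/N=C(/NC(=O)c1cnc2ccccc2c1)[Se]Cc1ccccc1)c1cnc2ccccc2c1` differs from compound 2 only at the group attached to selenium; in this assay compound 3 gives 26100 nM. Compound 1 thus has a higher number than compound 2 and a lower number than compound 3. Among the compounds with values here, the only step measured within this set is a 130-fold higher number from compound 2 to compound 3 (2.12 log units; beyond the scatter). Compound 4 `CS/C(=N\C(=O)c1cc2ccccc2s1)NC(=O)c1cc2ccccc2s1` is not yet measured. It differs from compound 1 in one place: a group of 2 heavy atoms (1 carbon, 1 sulfur; no ring) in place of a group of 2 heavy atoms (1 carbon, 1 selenium; no ring), on a carbon with a double bond to nitrogen. Within the data shown here, no measured pair shows the effect of exchanging selenium for sulfur at this position, and the step from compound 2 to compound 3 concerns a different part of the molecule, so it offers no guide to the size or direction of this change. Compound 4 is therefore expected to give 8000 nM, within a range from 2000 nM to 32000 nM. The expected step of a 1.4-fold higher number from compound 1 to compound 4 (0.15 log units; within the scatter) is an estimate that falls within the scatter, with wide bounds.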

Compound 4, concentration for 50% growth inhibition: 16800 nM
The estimate for compound 4 lay 2.1-fold (0.32 log units) below the measured number; the measured number falls inside the stated range.
By their numbers in this assay, from the lowest: compound 2; then compound 1; then compounds 4 and 3 (each within the scatter of the next).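

In this assay, putting sulfur in place of selenium, on a carbon with a double bond to nitrogen, gives a 3.0-fold higher number from compound 1 to compound 4 (0.48 log units; beyond the scatter). Going by these compounds alone, this is the only measured pair that isolates the choice of this atom, and it shows that the choice alone shifts the number: on the core of compound 1, the selenium compound is the stronger inhibitor of growth. No available measurement explains this shift.

This single pair cannot show whether the same exchange would shift the number in the same direction on the core of compound 2, or when the methyl group is replaced by the benzyl-type group of compound 3. The compounds shown also leave open how an amine or a longer chain such as ethylsulfanyl on this carbon would compare.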